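Trifluoromethylphenyl replaces nitrophenyl on the sulfur-bound carbon

The source may report more compounds than this note shows. Statements on the series, on what has been measured and on what is new or still open speak of the compounds shown alone.

Measured compounds:
compound 1, `Cc1cc(Nc2ccc(C(=O)/C=C/c3ccc4ccccc4c3)cc2)n2nc(SCc3cccc(Br)c3)nc2n1`: 270 nM
compound 2, `Cc1cc(Nc2ccc(C(=O)/C=C/c3ccc4ccccc4c3)cc2)n2nc(SCc3ccc([N+](=O)[O-])cc3)nc2n1`: 1130 nM

In a functional assay on SW-620 cells (Homo sapiens) for cytotoxicity, read by MTT assay, with stated times of 4 h and 72 h, tested at 5 uM (a higher number here means a weaker inhibitor, a lower number a stronger inhibitor), compound 1 gives 270 nM, and compound 2 gives 1130 nM. Compound 2 thus stands at the higher of the two numbers shown, with compound 1 as its only neighbour; the single measured step is a 4.2-fold higher number from compound 1 to compound 2 (0.62 log units; beyond the scatter). Compound 3, `Cc1cc(Nc2ccc(C(=O)/C=C/c3ccc4ccccc4c3)cc2)n2nc(SCc3ccccc3C(F)(F)F)nc2n1`, differs from compound 2 at the same place: 2-(trifluoromethyl)phenyl in place of 4-nitrophenyl on a saturated chain carbon bound to a sulfur. Going by the values given here, the one step that bears on this change is a 4.2-fold higher number from compound 1 to compound 2 (0.62 log units; beyond the scatter), which shows that the group on the saturated chain carbon bound to the sulfur can move the number beyond the scatter. Since the 4-nitrophenyl of compound 2 gave the higher number and compound 1 with 3-bromophenyl the lower one, a modest drop is expected for compound 3, an estimated step of a 2.3-fold lower number from compound 2 to compound 3 (0.35 log units; beyond the scatter). Compound 3 is therefore estimated at 500 nM, within a range of 200 nM to 1500 nM.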

Compound 3, half-maximal inhibitory concentration: 1240 nM
Compound 3: middle estimate off by 2.5-fold (0.39 log units), on the low side; measured number inside the range.
By their numbers in this assay, from the lowest: compound 1; then compounds 2 and 3 (each within the scatter of the next).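

In this assay, the result shows that exchanging 4-nitrophenyl for 2-(trifluoromethyl)phenyl on the saturated chain carbon bound to the sulfur leaves the number within the scatter, with a 1.1-fold higher number from compound 2 to compound 3 (0.04 log units; within the scatter), although the entering group carries no hydrogen-bond acceptors and the leaving one does. The 3-bromophenyl group remains apart from both, with a 4.6-fold higher number from compound 1 to compound 3 (0.66 log units; beyond the scatter), so compound 1 now has the lowest number against two different groups rather than one. Nothing given here accounts for this separation.

The compounds shown cannot tell whether the bromine itself or its place on the ring matters, which a 4-bromophenyl group would address. Going by these compounds, how an unsubstituted phenyl, an amine or a carboxylic acid would behave at this position also remains open.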